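Phenethylsulfanyl in place of pentylsulfanyl on the pyridine core

The source may hold more compounds than are shown below. What is called first, only, known or untested is meant among the compounds shown, and "the series" means these compounds.

Compound 1 `CCCCCSc1nc(C(F)(F)F)ccc1CNC(=O)C(C)c1ccc(NS(C)(=O)=O)c(F)c1` stands at the highest number among the two compounds of this series that carry a number, with 2.5 nM in an assay on CHO-K1 cells for antagonist activity at transient receptor potential cation channel subfamily V member 1 (Homo sapiens), read by FLIPR; on this read-out lower numbers stand for stronger inhibition and higher numbers for weaker inhibition. Its nearest neighbour is compound 2 `CC(C)CCSc1nc(C(F)(F)F)ccc1CNC(=O)C(C)c1ccc(NS(C)(=O)=O)c(F)c1`, which gives 0.7 nM; the step of a 3.6-fold lower number from compound 1 to compound 2 (0.55 log units; beyond the scatter) is a modest one and lies beyond the scatter. Compound 3 `CC(C(=O)NCc1ccc(C(F)(F)F)nc1SCCCO)c1ccc(NS(C)(=O)=O)c(F)c1`, in which the chain ends in a hydroxyl, is reported only as "not active" (no number reported) in this assay, without a number.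

Compound 4 `CC(C(=O)NCc1ccc(C(F)(F)F)nc1SCCc1ccccc1)c1ccc(NS(C)(=O)=O)c(F)c1` has not yet been measured. It differs from compound 1 by phenyl in place of propyl on a saturated chain carbon, two bonds along the chain from a sulfur. Among the measured compounds shown here, no measured step covers this change: the step from compound 1 to compound 2 concerns branching of the chain, and compound 3 shows what a hydroxyl at the chain end does, namely a loss of any reportable number. For the measured compounds named here, the aromatic ring of compound 4 has no precedent here. Given that a larger saturated chain end was tolerated in compound 2 with a 3.6-fold lower number from compound 1 to compound 2 (0.55 log units; beyond the scatter), the expectation for compound 4 is a number close to that of compound 1, and the step of a 1.3-fold lower number from compound 1 to compound 4 (0.10 log units; within the scatter) is expected to stay within or just beyond the scatter. The estimate for compound 4 in this assay is 2 nM, in a range from 0.5 nM to 8 nM.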

Compound 4, inhibition constant: 1.9 nM
The estimate for compound 4 lay 1.1-fold (0.02 log units) above the measured number; the range from low to high includes it.
By their numbers in this assay, from the lowest: compound 2; then compounds 4 and 1 (each within the scatter of the next).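

Phenyl in place of propyl, on a saturated chain carbon, two bonds along the chain from a sulfur, is accepted in this assay with a 1.3-fold lower number from compound 1 to compound 4 (0.12 log units; within the scatter) and so gives no separation between the phenethylsulfanyl and pentylsulfanyl compounds, which shows that this place can hold an aromatic ring and not only saturated chains. The ring does not match the branched chain, however: a 2.7-fold higher number from compound 2 to compound 4 (0.43 log units; beyond the scatter) is a modest step beyond the scatter, so the isopropyl group of compound 2 remains the better of the two at this place. No measurement of any other kind is available to account for either step.

The compounds shown leave open whether a substituted ring, such as a fluorophenyl or methoxyphenyl group, or a pyridyl ring in place of phenyl, would be accepted in the same way, and whether a shorter benzylsulfanyl or longer phenylpropylsulfanyl chain would move the number beyond the scatter. As far as these compounds go, it also remains open whether an amine or a carboxylic acid at the chain end would be reported as not active, as compound 3 with its hydroxyl is.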